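The source may hold more compounds than are shown below. What is called first, only, known or untested is meant among the compounds shown, and "the series" means these compounds.

Measured in an ADME assay on L6 cells (Rattus norvegicus) for cytotoxicity, read by resazurin assay, with a stated time of 72 h; a lower number here means a stronger inhibitor, a higher number a weaker inhibitor:
- compound 1 `O=[N+]([O-])c1ncn(CCCNS(=O)(=O)c2cc(Cl)sc2Cl)n1`: 119000 nM
- compound 2 `O=[N+]([O-])c1nccn1CCCNS(=O)(=O)c1cc(Cl)c(Cl)s1`: 75000 nM
- compound 3 `O=C(NCCCn1cnc([N+](=O)[O-])n1)c1ccsc1`: > 356000 nM (a limit)

Compound 3 gives no exact number, only > 356000 nM, which is a limit of the assay. In the set, this is the limit of > 356000 nM in this assay, at which 1 of the 3 values shown sits.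

Compound 4 `O=C(NCCCn1cnc([N+](=O)[O-])n1)c1ccnc(Cl)c1` carries 2-chloropyridin-4-yl in place of thiophen-3-yl on a carbonyl carbon.

For the measured compounds named here, no measured pair shows this change. The expectation for this assay therefore leans on compound 1 at 119000 nM and compound 2 at 75000 nM, both of which reach real numbers. The expected change is an at least 1.9-fold lower number from compound 3 to compound 4 (0.29 log units; that floor lies within the scatter), a modest one toward a lower number. For compound 4 the estimated value is 180000 nM, with an expected range of 60000 nM to 330000 nM.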

Compound 4, half-maximal inhibitory concentration: > 322000 nM
Compound 4 ended at the assay's limit; the forecaster's own chance of this, stated with the estimate: 40%; at least 1.7-fold (0.25 log units) between middle value and limit.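

For the compounds shown here, no step from compound 3 to compound 4 can be read: each compound's value is only a limit of the assay. Going by these compounds, whether thiophen-3-yl or 2-chloropyridin-4-yl on the carbonyl carbon gives the lower number remains open.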